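Notes on the series: allyloxy to ethylsulfanyl

This account rests on a few compounds, and the source may have more. Where it says the series, first, only, none or still open, it means among the compounds named here.

Measured in a functional assay on the whole organism (strain Sprague-Dawley) for inhibition, with Rattus norvegicus as the target, with a stated time of 10 min; a lower number here means that less compound is needed, a higher number that more compound is needed for the effect:
- compound 1 `O=C(O)c1cnc(-c2ccccc2)[nH]c1=O`: 50 mg/kg
- compound 2 `O=C(O)c1cnc(-c2ccccc2O)[nH]c1=O`: > 5 mg/kg (a limit)
- compound 3 `C=CCOc1ccccc1-c1ncc(C(=O)O)c(=O)[nH]1`: 0.5 mg/kg

Compound 3 at 0.5 mg/kg has the lower of the two true numbers in this assay. The entry for compound 2 is a limit. Going by the values given here, two measured steps bear on the next change: a 100-fold lower number from compound 1 to compound 3 (2.00 log units; beyond the scatter), and an at least 10-fold lower number from compound 2 to compound 3 (1.00 log units; beyond the scatter). Both show large gains tied to the allyloxy group. Compound 4 `CCSc1ccccc1-c1ncc(C(=O)O)c(=O)[nH]1` keeps a chain at that place, with ethylsulfanyl in place of allyloxy on an aromatic carbon. Among the compounds with values here, no measured step exchanges allyloxy for ethylsulfanyl, so the expectation is only a small loss, not a return towards compound 1. The estimated step is a 2.0-fold higher number from compound 3 to compound 4 (0.30 log units; within the scatter). For compound 4 the expected value is 1 mg/kg, with an estimated range of 0.2 mg/kg to 5 mg/kg.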

Compound 4, dose for 50% inhibition: 25 mg/kg
Compound 4: the middle estimate sits 25-fold (1.40 log units) below what was measured; the whole stated range lies below it.
By their numbers in this assay, from the lowest: compound 3; then compounds 4 and 1 (each within the scatter of the next).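

In this assay, a chain at this place is not enough to hold the gain: ethylsulfanyl in place of allyloxy gives a 50-fold higher number from compound 3 to compound 4 (1.70 log units; beyond the scatter). Against hydrogen at this place, ethylsulfanyl gives a 2.0-fold lower number from compound 1 to compound 4 (0.30 log units; within the scatter), so the gain seen with allyloxy is not kept. The step from compound 2 cannot be read, as compound 2 carries a limit: the limit of > 5 mg/kg in this assay, at which 1 of the 4 values shown sits.

Ethylsulfanyl differs from allyloxy in both the sulfur in place of oxygen and the loss of the double bond, and the compounds shown do not separate the two. An ethoxy or an allylsulfanyl group would separate them.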